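Swapping a propyl ether for an unsaturated ester

The compounds below may be only part of what the source reports. "The series", "measured", "known", "first", "only" and "open" are said of these compounds alone.

In a functional assay on KB cells (Homo sapiens) for cytotoxicity (a higher number here means a weaker inhibitor, a lower number a stronger inhibitor), two compounds have numbers so far:
compound 1 `CCCOC1=CC(=O)c2ccccc2C1=O` gives 49400 nM
compound 2 `Cc1ccc(S(=O)(=O)Oc2cccc3c2C(=O)C=CC3=O)cc1` gives 10700 nM

Compound 1 at 49400 nM holds the higher of the two numbers, which makes it the weaker inhibitor by more than the scatter. Compound 3 `C/C=C/C(=O)OC1=CC(=O)c2ccccc2C1=O` keeps the core of compound 1 and changes one group (prop-1-en-1-yl)carbonyl in place of propyl on an oxygen on an unsaturated carbon with (prop-1-en-1-yl)carbonyl in place of propyl on an oxygen on an unsaturated carbon. For the measured compounds named here, no measured pair tests this change, so its size remains a judgement. Compound 2 at 10700 nM shows that a clearly lower number occurs in this small set. A move toward a stronger inhibitor, moderately beyond the scatter, is expected, estimated as a 3.3-fold lower number from compound 1 to compound 3 (0.52 log units; beyond the scatter) in this assay. Compound 3 is expected at about 15000 nM with an estimated range from 4000 nM to 50000 nM in this measurement.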

Compound 3, half-maximal inhibitory concentration: 64200 nM
For compound 3 the middle estimate is 4.3-fold (0.63 log units) below the measured one; measured number outside the range, above it.
By their numbers in this assay, from the lowest: compound 2; then compounds 1 and 3 (each within the scatter of the next).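

In this assay, for the compounds shown here, (prop-1-en-1-yl)carbonyl in place of propyl on an oxygen on an unsaturated carbon gives a 1.3-fold higher number from compound 1 to compound 3 (0.11 log units; within the scatter) and so forms the first direct pair at this place. The exchange of propoxy for ((prop-1-en-1-yl)carbonyl)oxy adds heavy atoms, double bonds and a hydrogen-bond acceptor, yet compound 3 stays level with compound 1 within the scatter, so this position tolerates the change in this assay. Nothing measured here bears on why the two compounds stand level.

Going by these compounds, whether an aminoethyl group or a longer chain such as hexyl on this oxygen would separate from compound 1 remains open. Also open, on these data alone, is how a saturated butanoyl group would read at the same place, which would test the carbonyl apart from the double bond.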